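Extending the alkoxy chain of the shared core

The source may report more compounds than this note shows. Statements on the series, on what has been measured and on what is new or still open speak of the compounds shown alone.

For the measured compounds named here, compound 1 `COc1cc(C(=O)N(C)C)nn1-c1ccccc1` gives 47.5% in a functional assay on the whole organism (strain Wistar) for inhibition, with Rattus norvegicus as the target, read by paw edema, with stated times of 30 min and 3 h, at a dose of 100 mg/kg by the oral route (on this read-out higher numbers stand for more inhibition at the one dose given (going by the name of the read-out) and lower numbers for less inhibition), and stands highest of the two numbers known so far. Compound 2 `COc1cc(C(=O)N2CCCC2)nn1-c1ccccc1` gives 29.2% in this assay; the gap, a number 18.3 percentage points lower from compound 1 to compound 2 (beyond the scatter), concerns the amide only. Compound 3 `CC(C)CCOc1cc(C(=O)N(C)C)nn1-c1ccccc1` differs from compound 1 at another place, (isobutyl in place of hydrogen on a saturated chain carbon bound to an oxygen on an aromatic ring), methoxy becoming isopentyloxy. Going by the values given here, no measured step touches this alkoxy chain, so the one known step offers no direct guide. The step of a number 2.5 percentage points lower from compound 1 to compound 3 (within the scatter) is therefore expected to stay within the scatter. Compound 3 is estimated at 45%, in the range 25% to 65%.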

Compound 3, a percentage reported as inhibition, in the whole organism at one dose (the size of the read-out at that dose, not a potency): 25.3%
Estimate against measurement, compound 3: 19.7 percentage points above, and the stated range covers the measured number.
By their numbers in this assay, from the lowest: compounds 3 and 2 (each within the scatter of the next); then compound 1.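

The alkoxy chain turns out to be a place that matters in this assay: with methoxy becoming isopentyloxy, the read-out falls by a number 22.2 percentage points lower from compound 1 to compound 3 (beyond the scatter). So a change away from the amide also moves the number beyond the scatter, and of the two chains shown on the dimethylamide, methoxy gives the higher inhibition. Nothing available explains this drop.

With only these two chains shown, it stays open how an ethoxy or butoxy chain, a benzyloxy group or a free hydroxyl would read. On these data alone, whether isopentyloxy would have the same effect alongside the pyrrolidin-1-yl amide is also open.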